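A few compounds are considered here, and "the series" means these few. Any claim that something is new, unique, unknown or untested is made for them only; others in the source may bear on it.

In an assay on isolated protein for inhibition of glutathione S-transferase Mu 2 (Homo sapiens), with a stated time of 10 min (a lower number here means a stronger inhibitor, a higher number a weaker inhibitor), the three measured compounds gave these values. Compound 1 `Cc1ccccc1NC(=O)CCC(=O)OCCCCCCSc1ccc([N+](=O)[O-])c2nonc12`: 440 nM. Compound 2 `O=C(CCC(=O)OCCCCCCSc1ccc([N+](=O)[O-])c2nonc12)Nc1ccc(F)cc1`: 320 nM. Compound 3 `COc1ccc(NC(=O)CCC(=O)OCCCCCCSc2ccc([N+](=O)[O-])c3nonc23)cc1`: 130 nM.

Compound 3 has the lowest number of the three; it is separated from compound 2 by a 2.5-fold lower number from compound 2 to compound 3 (0.39 log units; beyond the scatter) and from compound 1 by a 3.4-fold lower number from compound 1 to compound 3 (0.53 log units; beyond the scatter), both beyond the scatter, so compound 3 is the strongest inhibitor measured so far. Compound 4 `CCN(CC)CCCNC(=O)CCC(=O)OCCCCCCSc1ccc([N+](=O)[O-])c2nonc12` differs from compound 3 by 3-(diethylamino)propyl in place of 4-methoxyphenyl on an amide-type nitrogen. All three measured steps, including a 1.4-fold lower number from compound 1 to compound 2 (0.14 log units; within the scatter), exchange one aromatic group for another on the amide-type nitrogen; none replaces the ring with a chain, so the step to compound 4 is not directly covered. A modest weakening is expected, a 3.1-fold higher number from compound 3 to compound 4 (0.49 log units; beyond the scatter), with compound 4 estimated at 400 nM, in the range 100 nM to 1500 nM.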

Compound 4, half-maximal inhibitory concentration: 440 nM
Compound 4: middle estimate off by 1.1-fold (0.04 log units), on the low side; measured number inside the range.
By their numbers in this assay, from the lowest: compound 3; then compounds 2, 1 and 4 (each within the scatter of the next).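

Replacing an aromatic ring on the amide-type nitrogen with a ringless chain does not by itself cost inhibition: 3-(diethylamino)propyl gives no change at the digits printed from compound 1 to compound 4 (within the scatter) and a 1.4-fold higher number from compound 2 to compound 4 (0.14 log units; within the scatter). Only the 4-methoxyphenyl group of compound 3 stands apart, with a 3.4-fold higher number from compound 3 to compound 4 (0.53 log units; beyond the scatter), so that group, not aromatic rings in general, sets the strongest inhibitor here. No measurement at hand explains this.

Still open, as far as these compounds go, is whether a plain hexyl chain without the amine would match 3-(diethylamino)propyl. Also open, from the compounds shown here alone, is how a carboxylic acid at the end of the chain, or a 4-ethoxyphenyl group, would compare.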